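Flipping one stereocentre in compound 1

The source may hold more compounds than are shown below. What is called first, only, known or untested is meant among the compounds shown, and "the series" means these compounds.

Measured in a functional assay on HCT-116 cells (Homo sapiens) for antiproliferative activity; a higher number here means that more compound is needed for the effect, a lower number that less compound is needed
Compound 1 `Cc1c2c(n3c1CCN(C(=O)[C@H](C)N)CC[C@H](C)Nc1cc-3ccc1C(N)=O)CC(C)(C)CC2=O` gives 314 nM
Compound 2 `Cc1c2c(n3c1CCCN(C(=O)[C@@H](C)N)[C@H](C)CNc1cc-3ccc1C(N)=O)CC(C)(C)CC2=O` gives > 5000 nM
Compound 3 `Cc1c2c(n3c1CC(=O)N(C)CC[C@H](C)Nc1cc-3ccc1C(N)=O)CC(C)(C)CC2=O` gives 247 nM

The reading for compound 2 is a limit of the assay and not a number. Compound 1 (314 nM) and compound 3 (247 nM) lie within the scatter of each other, so these two cannot be told apart, and compound 1 is the starting point here.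

Compound 4 `Cc1c2c(n3c1CCN(C(=O)[C@@H](C)N)CC[C@H](C)Nc1cc-3ccc1C(N)=O)CC(C)(C)CC2=O` has not yet been measured. Its structure differs from that of compound 1 as follows: the two compounds have the same atoms and bonds and differ only in configuration as drawn: 1 of 2 stereo elements differ; a stereocentre at a saturated chain carbon is drawn S in compound 1 and R in compound 4 In words, the two compounds have the same atoms and bonds, and a stereocentre at a saturated chain carbon is drawn S in compound 1 and R in compound 4.

Going by the values given here, no measured pair shows what such a flip does, so the expectation is loose. A modest rise in the number is expected in this assay, meaning that somewhat more compound would be needed, and the estimated shift (a 1.8-fold higher number from compound 1 to compound 4 (0.24 log units; within the scatter)) may not clear the scatter. For compound 4 the estimated value is 550 nM with an expected range from 150 nM to 2500 nM and no narrower claim.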

Compound 4, half-maximal effective concentration in the HCT-116 assay: 710 nM
For compound 4 the middle estimate is 1.3-fold (0.11 log units) below the measured one; the measured number falls inside the stated range.
By their numbers in the HCT-116 assay, from the lowest: compounds 3 and 1 (each within the scatter of the next); then compound 4. At a limit, above all of these: compound 2.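

In the HCT-116 assay, turning this one saturated chain carbon from S to R gives a modest but readable step: a 2.3-fold higher number from compound 1 to compound 4 (0.35 log units; beyond the scatter). Compounds 1, 2 and 3 differ from one another in more than one place, so they gave no reading of this stereocentre on its own. The step can be traced to the configuration at this carbon alone, because nothing else in the structure changes: the fact that compounds 1 and 4 differ only in the configuration as drawn

In a physicochemical assay for solubility (a higher number here means a more soluble compound, a lower number a less soluble compound), compound 1 gives > 100 ug/mL, which is a limit of the assay and not a number. In the physicochemical assay compound 4 gives > 100 ug/mL, which is also a limit of the assay and not a number. As far as these compounds go, in the physicochemical assay the step between the two compounds cannot be read, since both sit at a limit of the assay and neither gives a number: the limit of > 100 ug/mL in the physicochemical assay, at which 2 of the 2 values shown sit. Still open is whether a flip at the other stereocentre would give a step of similar size, and whether this one would hold with a carboxylic acid in place of the amine.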